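A few compounds are considered here, and "the series" means these few. Any claim that something is new, unique, unknown or untested is made for them only; others in the source may bear on it.

Measured compounds in a functional assay on MCF7 cells (Homo sapiens) for inhibition, read by MTT assay, with a stated time of 72 h; a lower number here means a stronger inhibitor, a higher number a weaker inhibitor:
Compound 1 `CC(C)n1ncc2c(C(=O)NCc3cn(-c4ccccc4)nn3)cccc21`: compound 1 gives > 40000 nM, a limit of the assay and not a number.
Compound 2 `Cc1ccc(-n2cc(CNC(=O)c3cccc4c3cnn4C(C)C)nn2)cc1C`: compound 2 gives > 40000 nM, likewise a limit.
Compound 3 `CC(C)n1ncc2c(C(=O)NCc3cn(-c4ccc(I)cc4)nn3)cccc21`: compound 3 gives > 40000 nM, again a limit.

Compound 3 cannot be placed on the numbers shown: its own value is a limit, and the two further values shown are limits too, so all three rest on (the limit of > 40000 nM in this assay, at which 3 of the 3 values shown sit). The steps among the measured compounds, a step that the two limits leave unreadable from compound 1 to compound 2, a step that the two limits leave unreadable from compound 1 to compound 3 and a step that the two limits leave unreadable from compound 2 to compound 3, can be read neither in size nor in direction because the limit of > 40000 nM in this assay, at which 3 of the 3 values shown sit, holds both ends of each of them.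

Compound 4 `CC(C)n1ncc2c(C(=O)NCc3cn(-c4ccc(F)cc4)nn3)cccc21` differs from compound 3 by fluoro in place of iodo on an aromatic carbon. Among the compounds with values here, since none of the measured steps is readable, none can set a size for this one; what they do show is that varying the group on the aromatic nitrogen among phenyl, 3,4-dimethylphenyl and 4-iodophenyl has not brought any compound below the limit. The step of a number no higher from compound 3 to compound 4 (the limit leaves the size open) is therefore expected to be nothing beyond the scatter, and the result is most likely once more a limit. For compound 4 the estimate in this assay is 40000 nM, within 15000 nM to 100000 nM.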

Compound 4, half-maximal inhibitory concentration: > 40000 nM
Compound 4 was reported as a limit (the forecaster's own chance of this, stated with the estimate: 85%); the middle value lies on the limit itself.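

Within the data shown here, no step to compound 4 from compound 1, compound 2 or compound 3 can be read in this assay, in size or in direction, because both ends of each step rest on a limit: the limit of > 40000 nM in this assay, at which 4 of the 4 values shown sit. The compounds shown leave open whether any group on the aromatic nitrogen gives measurable inhibition, and how these four compounds rank against one another.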